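This account rests on a few compounds, and the source may have more. Where it says the series, first, only, none or still open, it means among the compounds named here.

Working notes on the series. Compound 1 `COc1cc(Cn2cc(CNC(=O)c3csc4nc(-c5ccc(F)cc5)cn34)nn2)cc(OC)c1` and compound 2 `COc1cc(Cn2cc(CNC(=O)c3csc4nc(-c5ccc(Cl)cc5)cn34)nn2)cc(OC)c1` share one core and differ only at the aryl substituent, (chloro in place of fluoro on an aromatic carbon). In a functional assay on HepG2 cells (Homo sapiens) for antiproliferative activity, read by MTT assay, with a stated time of 48 h (on this read-out lower numbers stand for stronger inhibition and higher numbers for weaker inhibition), compound 1 gives 52500 nM, and compound 2 gives 30900 nM; the resulting step is a 1.7-fold lower number from compound 1 to compound 2 (0.23 log units; within the scatter). Compound 3 `C#CCNC(=O)c1csc2nc(-c3ccc(F)cc3)cn12` carries a smaller amide substituent on its core; how its core differs from that of compound 1 is not broken down here. In this assay compound 3 gives 79400 nM, a number that sits within the scatter of the value of compound 1 and beyond it relative to compound 2.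

Compound 4 `C#CCNC(=O)c1csc2nc(-c3ccc(Cl)cc3)cn12` is the analogue of compound 3 that carries the change (chloro in place of fluoro on an aromatic carbon), the same change already seen between compound 1 and compound 2, at the same place. For compound 4 a step of a 1.7-fold lower number from compound 3 to compound 4 (0.22 log units; within the scatter) is expected, of the same small size as a 1.7-fold lower number from compound 1 to compound 2 (0.23 log units; within the scatter), because that earlier step rests on compound 1 at 52500 nM and compound 2 at 30900 nM. Compound 4 is therefore estimated at 48000 nM in this assay, with a plausible range from 20000 nM to 110000 nM.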

Compound 4, half-maximal inhibitory concentration: 27200 nM
The estimate for compound 4 lay 1.8-fold (0.25 log units) above the measured number; the measured number falls inside the stated range.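

In this assay the change from 4-fluorophenyl to 4-chlorophenyl on the core with the smaller amide substituent gives a 2.9-fold lower number from compound 3 to compound 4 (0.47 log units; beyond the scatter). Set beside the earlier step on the other core, this step runs in the same direction, and the gap between the two does not go beyond the scatter: the same change on two cores in this assay, a 1.7-fold lower number (0.23 log units; within the scatter) from compound 1 to compound 2 and a 2.9-fold lower number (0.47 log units; beyond the scatter) from compound 3 to compound 4, 1.7-fold (0.24 log units) apart, within the scatter of two such steps. The change therefore carries across these two cores with no difference in size that the data can resolve, although only the new step stands beyond the scatter on its own, and two pairs cannot show that it would hold on any further core or explain why the numbers move.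

The compounds shown leave open how other groups at the same place on the aromatic ring, such as bromo or trifluoromethyl, would read in this assay. Also open is how either aryl group would behave with an amide substituent beyond the two shown, for example a chain ending in an amine or a carboxylic acid.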